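From thiophen-2-yl to 3-fluoropyridin-2-yl on compound 2

The source may hold more compounds than are shown below. What is called first, only, known or untested is meant among the compounds shown, and "the series" means these compounds.

In an ADME assay on a cell-free system (plasma, Rattus norvegicus) for metabolic stability, read by LC-MS, with a stated time of 4 h, tested at 100 uM (on this read-out lower numbers stand for a less stable compound and higher numbers for a more stable compound), compound 1 `O=C(NO)c1cc(F)c(Cn2nnc(-c3ccco3)n2)c(F)c1` gives 100%, while compound 2 `Cn1c(Sc2c(F)cc(C(=O)NO)cc2F)nnc1-c1cccs1` gives 87%. Compound 2 therefore holds the lower of the two numbers, and the gap lies beyond the usual scatter. Compound 3 `Cn1c(Sc2c(F)cc(C(=O)NO)cc2F)nnc1-c1ncccc1F` keeps the core of compound 2 but carries 3-fluoropyridin-2-yl in place of thiophen-2-yl on an aromatic carbon. Going by the values given here, no measured pair shows this change on its own. In this assay, the expected step of a number 1 percentage points higher from compound 2 to compound 3 (within the scatter) is estimated to stay within the scatter, with no firm direction. The value expected for compound 3 is 88%, with an estimated range from 72% to 100%.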

Compound 3, percent of the compound remaining: 100%
For compound 3 the middle estimate is 12 percentage points below the measured one, within the range that was stated.
By their numbers in this assay, from the lowest: compound 2; then compounds 1 and 3 (each within the scatter of the next).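

In this assay, placing 3-fluoropyridin-2-yl instead of thiophen-2-yl on the aromatic carbon between two ring nitrogen atoms gives a number 13 percentage points higher from compound 2 to compound 3 (beyond the scatter), and a higher number here means a more stable compound. Going by these compounds alone, this is the first comparison of compounds that differ in one place, and it shows that the group at this position can shift the read-out. Nothing measured here accounts for the step. As far as these compounds go, it remains open how pyridin-2-yl without the fluorine, or an amine, would read at this position.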